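A Second Chloro on the Shared Core: Expectation for Compound 4

This account rests on a few compounds, and the source may have more. Where it says the series, first, only, none or still open, it means among the compounds named here.

Compound 1, `ClCc1ccccc1Cn1cnc2c(Cl)nc(Cl)nc21`: 8510 nM
Compound 2, `ClCc1cccc(Cn2cnc3ncnc(Cl)c32)c1`: 6760 nM
Compound 3, `ClCc1cccc(Cn2cnc3c(Cl)ncnc32)c1`: > 100000 nM

Of the compounds shown here, three have been measured in a functional assay on SK-MEL-2 cells (Homo sapiens) for cytotoxicity, read by sulforhodamine B assay, with a stated time of 48 h; a higher number here means that more compound is tolerated, a lower number that less compound is tolerated. Compound 2 gives the lowest of the two numbers shown, and its nearest neighbour is compound 1, which gives 8510 nM, a gap that lies within the scatter. For compound 3 the assay reports only a limit, > 100000 nM, and not a number; the limit itself is the one set by the assay at the limit of > 100000 nM in this assay, at which 1 of the 3 values shown sits.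

The unmeasured compound is compound 4, `ClCc1cccc(Cn2cnc3nc(Cl)nc(Cl)c32)c1`. It differs from compound 2 by chloro in place of hydrogen on an aromatic carbon, so the change is chloro in place of hydrogen on an aromatic carbon, at a position between two ring nitrogen atoms and meta to the chloro group already present. Among the measured compounds shown here, no step between measured compounds isolates this change, so no measured size can be quoted for it. Compound 1 carries two chloro groups on the same core and gives a number within the scatter of compound 2, which makes a step of similar size, or none beyond the scatter, the most plausible outcome in this assay. Compound 4 is therefore estimated at 8500 nM, with a range from 2500 nM to 30000 nM, an expected step of a 1.3-fold higher number from compound 2 to compound 4 (0.10 log units; within the scatter).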

Compound 4, concentration lethal to 50% of the cells: 7760 nM
Compound 4: middle estimate off by 1.1-fold (0.04 log units), on the high side; the range from low to high includes it.
By their numbers in this assay, from the lowest: compounds 2, 4 and 1 (each within the scatter of the next). At a limit, above all of these: compound 3.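

Chloro in place of hydrogen on an aromatic carbon, at the position between two ring nitrogen atoms, now has a measured size in this assay: a 1.1-fold higher number from compound 2 to compound 4 (0.06 log units; within the scatter). Among the compounds shown here, no earlier pair isolated this change, and this step shows that, on the shared core with a chloro group already present meta to this position, the added chloro group gives a number within the scatter of the number without it, so this one heavy atom at this position leaves no step that can be told apart in this read-out. Nothing measured for these compounds bears on why the two numbers lie so close.

Going by these compounds, whether this position tolerates other groups in the same way stays open, as an amine, a methoxy group or a longer chain in place of the chloro group could give a different number. On these data alone, compound 3 gives only a limit, > 100000 nM, so whether chloro in place of hydrogen at this position would give a step of similar size on its core also stays open.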